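The source may hold more compounds than are shown below. What is called first, only, known or untested is meant among the compounds shown, and "the series" means these compounds.

Compound 3 `Cc1nc(NC(C2CC2)C2CC2)c2nc(C)n(-c3ccc(F)cc3)c2n1` gives 91 nM in a functional assay on CHO cells for antagonist activity at corticotropin-releasing factor receptor 1 (Homo sapiens), read by cAMP accumulation (a higher number here means a weaker inhibitor, a lower number a stronger inhibitor), the second highest of the three numbers measured. Compound 2 `Cc1nc(NC(C2CC2)C2CC2)c2nc(C)n(-c3ccc(S(C)(=O)=O)cc3)c2n1` gives 140 nM, and the step of a 1.5-fold lower number from compound 2 to compound 3 (0.19 log units; within the scatter) lies within the scatter. Compound 1 `COc1ccc(-n2c(C)nc3c(NC(C4CC4)C4CC4)nc(C)nc32)c(C)c1` gives 14 nM, and the step of a 6.5-fold higher number from compound 1 to compound 3 (0.81 log units; beyond the scatter) is the only one beyond the scatter. Compound 4 `CCOc1ccc(-n2c(C)nc3c(NC(C4CC4)C4CC4)nc(C)nc32)cc1` differs from compound 3 by ethoxy in place of fluoro on an aromatic carbon. The step from compound 1 to compound 3 bears on this change, since it also exchanges an alkoxy-bearing aryl for the 4-fluorophenyl, though compound 1 carries a further methyl that compound 4 lacks. Compound 4 is therefore expected to show a modestly lower number, a 2.6-fold lower number from compound 3 to compound 4 (0.41 log units; beyond the scatter), and its estimate in this assay is 35 nM, with a range from 12 nM to 100 nM.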

Compound 4, inhibition constant: 20 nM
Beside the measured number, compound 4's estimate is 1.8-fold (0.24 log units) above it, and the stated range covers the measured number.
By their numbers in this assay, from the lowest: compounds 1 and 4 (each within the scatter of the next); then compounds 3 and 2 (each within the scatter of the next).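

In this assay, ethoxy at this position gives a 4.6-fold lower number from compound 3 to compound 4 (0.66 log units; beyond the scatter) and a 7.0-fold lower number from compound 2 to compound 4 (0.85 log units; beyond the scatter), so this substituent separates from both fluoro and methylsulfonyl, which did not separate from each other. With a 1.4-fold higher number from compound 1 to compound 4 (0.15 log units; within the scatter), the 4-ethoxyphenyl group stays within the scatter of 4-methoxy-2-methylphenyl, so the methyl carried by compound 1 is not needed to reach this range. Nothing measured here explains these steps. The compounds shown leave open how a longer chain such as butoxy, a hydroxyl or an amine would fare at this position.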